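The source may report more compounds than this note shows. Statements on the series, on what has been measured and on what is new or still open speak of the compounds shown alone.

Compound 1 `Cc1c(Cl)cccc1CCCCOc1ccc(C#Cc2ccc(F)c3c(CCCC(=O)O)c(C)n(CCCC(=O)O)c23)cc1` gives 99% in a functional assay on the whole organism for inhibition, with Cavia porcellus as the target, with stated times of 1 h and 10 min, at a dose of 0.3 mg/kg by the oral route; a lower number here means a weaker effect, a higher number a stronger effect of the compound at the dose given.
Compound 2 `Cc1c(CCCC(=O)O)c2cccc(/C=C/c3ccc(OCCCCc4c(F)c(F)cc(F)c4F)cc3)c2n1CC(=O)O` gives 9% in this assay.

Of these two numbers, compound 2 stands lowest, and compound 1 stands far above it, well beyond the scatter. Compound 3 `Cc1c(F)cccc1CCCCOc1ccc(/C=C/c2cccc3c(CCCC(=O)O)c(C)n(CC(=O)O)c23)cc1` has not yet been measured. It differs from compound 2 in one place: 3-fluoro-2-methylphenyl in place of 2,3,5,6-tetrafluorophenyl on a saturated chain carbon, four bonds along the chain from an oxygen on an aromatic ring. For the measured compounds named here, no step between measured compounds carries this same change, so its size cannot be read from earlier pairs. Going by the values given here, a rise of a number 31 percentage points higher from compound 2 to compound 3 (beyond the scatter) is expected, with wide uncertainty, since the only guide is the much higher number of compound 1, which gives 99% with a different linker and a different ring. Compound 3 is estimated at 40%, within 10% to 85%.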

Compound 3, a percentage reported as inhibition, in the whole organism at one dose (the size of the read-out at that dose, not a potency): 83%
Compound 3: middle estimate off by 43 percentage points, on the low side; low and high end bracket the measured number.
By their numbers in this assay, from the lowest: compound 2; then compound 3; then compound 1.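

In this assay, replacing 2,3,5,6-tetrafluorophenyl with 3-fluoro-2-methylphenyl gives a number 74 percentage points higher from compound 2 to compound 3 (beyond the scatter) with the rest of the molecule unchanged. The group on this saturated chain carbon, four bonds along the chain from an oxygen on an aromatic ring, can therefore change the oral read-out strongly on its own. Nothing at hand accounts for the size of this step.

Going by these compounds, the methyl group and the loss of fluorines arrive together, so their separate shares remain open. On these data alone, how an amine or a methoxy group on this ring would read also remains open.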